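Shortening the Phenylalkyl Amide Chain on Two Cores

The source may report more compounds than this note shows. Statements on the series, on what has been measured and on what is new or still open speak of the compounds shown alone.

Compound 1 `O=C(CCc1ccccc1)Nc1cccc(-c2nc3ccccc3[nH]2)c1`: 68000 nM
Compound 2 `O=C(CCCc1ccccc1)Nc1cccc(-c2nc3ccccc3[nH]2)c1`: 43000 nM
Compound 3 `O=C(CCCc1ccccc1)Nc1ccc(-c2nc3ccccc3[nH]2)cc1`: > 100000 nM

In an assay on cells for inhibition of matrix metalloproteinase-9 (Homo sapiens), read by fluorescence, with stated times of 15 min and 4 h (a lower number here means a stronger inhibitor, a higher number a weaker inhibitor), compound 2 gives 43000 nM. Compound 1 carries phenyl in place of benzyl on a saturated chain carbon, two bonds along the chain from a carbonyl carbon, and the step of a 1.6-fold higher number from compound 2 to compound 1 (0.20 log units; within the scatter) leaves the two values within the usual scatter of each other. Compound 3 has the same atoms as compound 2 joined differently; the difference between the two cores is not broken down here. For compound 3 only a limit of this assay is recorded, (the limit of > 100000 nM in this assay, at which 1 of the 3 values shown sits), so the value > 100000 nM is not a number.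

Compound 4 `O=C(CCc1ccccc1)Nc1ccc(-c2nc3ccccc3[nH]2)cc1` is not yet measured. It differs from compound 3 by phenyl in place of benzyl on a saturated chain carbon, two bonds along the chain from a carbonyl carbon, the same change as from compound 2 to compound 1, at the same place. Since that earlier step was within the scatter, compound 4 is expected to sit close to compound 3, with an estimated step that the limit leaves unreadable from compound 3 to compound 4. The estimate for compound 4 in this assay is 150000 nM, in the range 60000 nM to 400000 nM, and most likely the assay again reports only a limit.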

Compound 4, half-maximal inhibitory concentration: 29000 nM
Beside the measured number, compound 4's estimate is 5.2-fold (0.71 log units) above it; measured number below the stated range.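

In this assay, putting phenyl in place of benzyl on a saturated chain carbon, two bonds along the chain from a carbonyl carbon, gives an at least 3.4-fold lower number from compound 3 to compound 4 (0.53 log units; beyond the scatter), although the full size of this step cannot be read. Compound 3 gives > 100000 nM, which is a limit of the assay and not a number. The change therefore does not act alike on the two cores, but two pairs set no rule for any further core and do not show what lies behind the difference: the same change on two cores in this assay, a 1.6-fold higher number (0.20 log units; within the scatter) from compound 2 to compound 1 and an at least 3.4-fold lower number (0.53 log units; beyond the scatter) from compound 3 to compound 4, at least 5.4-fold (0.73 log units) apart, beyond the scatter of two such steps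

The compounds shown leave open whether the gap between the two cores would persist with a longer chain than 3-phenylpropyl or with a shorter one, such as benzyl on the amide carbonyl in place of phenethyl. They also leave open how either core would respond if an amine or a carboxylic acid took the place of the phenyl group on the chain.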